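Amide aryl swap and metabolic stability in the series

A few compounds are considered here, and "the series" means these few. Any claim that something is new, unique, unknown or untested is made for them only; others in the source may bear on it.

The series shares one core carrying an amide-type nitrogen, and the aryl on that nitrogen is what varies. Compound 1 `COc1ccc2nc(C)cc(OCC(=O)Nc3ccc4c(c3)CCC4)c2c1` carries a 2,3-dihydro-1H-inden-5-yl there; in an ADME assay on liver (Homo sapiens) for metabolic stability, read by LC-MS, using S9 fraction, tested at 2 uM (a lower number here means slower removal, a higher number faster removal of the compound), compound 1 gives 16.9 mL/min/kg. Compound 2 `COc1ccc2nc(C)cc(OCC(=O)Nc3ccc(C)c(C)c3)c2c1` carries a 3,4-dimethylphenyl instead, and in this assay compound 2 gives 16.2 mL/min/kg. The step of a 1.0-fold lower number from compound 1 to compound 2 (0.02 log units; within the scatter) shows that the two measured compounds sit within the scatter of each other, so on the numbers shown compound 2 stands level with compound 1.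

Among the measured compounds shown here, compound 3 `CCc1ccc(NC(=O)COc2cc(C)nc3ccc(OC)cc23)cc1` is not yet measured. 4-ethylphenyl in place of 3,4-dimethylphenyl on an amide-type nitrogen The only measured step that bears on this change is a 1.0-fold lower number from compound 1 to compound 2 (0.02 log units; within the scatter), where exchanging one aryl for another on the same nitrogen left the clearance unchanged. For the measured compounds named here, nothing measured so far separates one carbon-only aryl from another at this position. For compound 3 the expected step is a 1.0-fold higher number from compound 2 to compound 3 (0.02 log units; within the scatter), that is, none beyond the scatter. In this assay compound 3 is therefore estimated at 17 mL/min/kg, with a range from 9 mL/min/kg to 34 mL/min/kg.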

Compound 3, clearance in the liver assay: 16.6 mL/min/kg
For compound 3 the middle estimate is 1.0-fold (0.01 log units) above the measured one, and the stated range covers the measured number.
By their numbers in the liver assay, from the lowest: compounds 2, 3 and 1 (each within the scatter of the next).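

In the liver assay the third carbon-only aryl on the amide-type nitrogen does not separate the series: a 1.0-fold higher number from compound 2 to compound 3 (0.01 log units; within the scatter), and a 1.0-fold lower number from compound 1 to compound 3 (0.01 log units; within the scatter), so clearance stays level across all three aryl groups. A second read-out does tell two of these aryl groups apart: in a physicochemical assay for solubility, read by HPLC, measured as thermodynamic solubility, with a stated time of 24 h, at pH 1.5 (a lower number here means a less soluble compound, a higher number a more soluble compound), compound 2 gives 80000 nM and compound 3 gives 790000 nM. Exchanging 3,4-dimethylphenyl for 4-ethylphenyl keeps the same atoms, joined differently, yet this one change on the amide-type nitrogen leaves clearance level while it separates the two compounds in solubility, so at this position the two read-outs do not move together: the measured solubility of compound 2, 80000 nM, and of compound 3, 790000 nM, a 9.9-fold higher number (0.99 log units; beyond the scatter)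

This single pair cannot say whether the difference in solubility follows from the ethyl chain itself or from the loss of the 3-methyl group, and no solubility number for compound 1 is shown beside it. Also open, from the compounds shown here alone, is whether clearance stays level once the aryl carries something other than carbon, such as an amine or a carboxylic acid, or a longer chain such as butyl.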